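From azidomethyl to prop-1-en-1-yl on a carbonyl carbon

The source may hold more compounds than are shown below. What is called first, only, known or untested is meant among the compounds shown, and "the series" means these compounds.

For the measured compounds named here, in a functional assay on KYSE-450 cells (Homo sapiens) for inhibition, read by MTT assay, with a stated time of 48 h (a higher number here means a weaker inhibitor, a lower number a stronger inhibitor), compound 2 (`COc1ccc(CN(C(=O)CN=[N+]=[N-])c2cc(OC)c(OC)c(OC)c2)cc1O`) gives 160 nM, the lower of the two numbers so far and beyond the scatter from compound 1 (`C/C=C/C(=O)N(Cc1ccc(OC)c([N+](=O)[O-])c1)c1cc(OC)c(OC)c(OC)c1`), which gives 510 nM. Compound 3 (`C/C=C/C(=O)N(Cc1ccc(OC)c(O)c1)c1cc(OC)c(OC)c(OC)c1`) has prop-1-en-1-yl in place of azidomethyl on a carbonyl carbon. Going by the values given here, compound 1, at 510 nM, also carries prop-1-en-1-yl, but it differs from compound 2 in more than one place, so no measured step isolates this change. The expected change is none beyond the scatter, with an estimated 1.3-fold higher number from compound 2 to compound 3 (0.10 log units; within the scatter). In this assay, compound 3 is estimated at 200 nM, with an expected range of 60 nM to 650 nM.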

Compound 3, half-maximal inhibitory concentration: 67 nM
Beside the measured number, compound 3's estimate is 3.0-fold (0.47 log units) above it; measured number inside the range.
By their numbers in this assay, from the lowest: compound 3; then compound 2; then compound 1.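

In this assay the carbonyl position proves responsive: prop-1-en-1-yl in place of azidomethyl gives a 2.4-fold lower number from compound 2 to compound 3 (0.38 log units; beyond the scatter) on the same remaining structure. The aromatic carbon responds as well, since hydroxy in place of nitro gives a 7.6-fold lower number from compound 1 to compound 3 (0.88 log units; beyond the scatter) with prop-1-en-1-yl held constant, which leaves compound 3 lowest of the three. No measurement shown accounts for either step.

The compounds shown leave open how a saturated propyl chain on the carbonyl carbon would compare with prop-1-en-1-yl. On these data alone, whether an amine on the aromatic carbon would match hydroxy also remains open.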